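The compounds below may be only part of what the source reports. "The series", "measured", "known", "first", "only" and "open" are said of these compounds alone.

Measured so far:
compound 1, `O=C(O)Cc1sc(C(c2ccc(F)cc2)c2ccc(F)cc2)nc1-c1ccccc1`, 16 nM;
compound 2, `O=C(O)Cc1sc(C(c2ccccc2)c2ccc(F)c(F)c2)nc1-c1ccc(F)cc1`, 10 nM;
compound 3, `COc1ccc(C(c2ccccc2)c2nc(-c3ccc(Cl)cc3)c(CC(=O)O)s2)cc1`, 8.4 nM.

In an in vitro assay on HEK385-7 cells for displacement of a labelled ligand from prostaglandin D2 receptor 2 (Homo sapiens) (a higher number here means a weaker inhibitor, a lower number a stronger inhibitor), compound 2 gives 10 nM, the second highest of the three numbers. Its nearest neighbour is compound 3 at 8.4 nM, within the scatter of compound 2, and its furthest is compound 1 at 16 nM, also within the scatter. Among the measured compounds shown here, the three measured compounds therefore sit together, with no step among them that can be read as a real difference.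

The step to compound 4, `O=C(O)Cc1sc(C(c2ccccc2)c2ccc(O)cc2)nc1-c1ccc(F)cc1`, is the change (4-hydroxyphenyl in place of 3,4-difluorophenyl on a saturated chain carbon bound to two aromatic carbons). For the measured compounds named here, no measured pair shows this kind of change, so the data give no step to lean on. Because the three measured compounds cluster within the scatter in this assay and compound 3 gives 8.4 nM with a different group at the same place, compound 4 is expected to stay close to compound 2, with at most a small move toward a higher number, not clearly beyond the scatter; the expected step is a 1.5-fold higher number from compound 2 to compound 4 (0.18 log units; within the scatter).

Compound 4 is estimated at 15 nM, with a range from 5 nM to 45 nM.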

Compound 4, half-maximal inhibitory concentration: 3.4 nM
Estimate against measurement, compound 4: 4.4-fold (0.64 log units) above, outside the stated range (below it).
By their numbers in this assay, from the lowest: compound 4; then compounds 3, 2 and 1 (each within the scatter of the next).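

Placing 4-hydroxyphenyl in place of 3,4-difluorophenyl on a saturated chain carbon bound to two aromatic carbons gives, in this assay, a 2.9-fold lower number from compound 2 to compound 4 (0.47 log units; beyond the scatter), the only step in this set that can be read, and it lies beyond the scatter. It shows that this position responds to a change of group, and that a group with a hydrogen-bond donor and a hydrogen-bond acceptor is accepted there in place of one with neither, although the step is modest. Nothing available explains this step.

Compound 1 and compound 3 differ from compound 4 in more than one place, so they cannot separate the gain of the hydroxyl from the loss of the two fluorines. From the compounds shown here alone, whether an amine or a carboxylic acid on that phenyl ring would follow the hydroxyl remains open.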